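Pyridin-3-yl for thiazol-2-yl on a shared core

This account rests on a few compounds, and the source may have more. Where it says the series, first, only, none or still open, it means among the compounds named here.

In an ADME assay on microsomes from liver (Homo sapiens) for metabolic stability (on this read-out lower numbers stand for slow clearance and higher numbers for fast clearance), compound 1 `O=c1n(Cc2nc(-c3nccs3)cn2CCCCO)c2cnccc2n1C1CC1` gives < 8 mL.min-1.g-1, which is a limit of the assay rather than a number (the limit of < 8 mL.min-1.g-1 in this assay, at which 1 of the 3 values shown sits). Compound 3 `O=c1n(Cc2nc3c(n2CCCCO)CCCC3)c2cnccc2n1C1CC1` gives 65 mL.min-1.g-1 in this assay. Compound 2 `CC(C)n1nc(Cn2nc3c(c2CCCCO)CCCC3)c2ccccc21`, which rests on a different core, gives > 320 mL.min-1.g-1 in this assay, again only a limit (the limit of > 320 mL.min-1.g-1 in this assay, at which 1 of the 3 values shown sits). Compound 4 `O=c1n(Cc2nc(-c3cccnc3)cn2CCCCO)c2cnccc2n1C1CC1` has not yet been measured; it differs from compound 1 by pyridin-3-yl in place of 1,3-thiazol-2-yl on an aromatic carbon. Going by the values given here, no measured pair shows this change, so the step in this assay is expected to be modest and, if anything, upward: an at least 1.5-fold higher number from compound 1 to compound 4 (0.17 log units; that floor lies within the scatter). Compound 4 is estimated at 12 mL.min-1.g-1, between 5 mL.min-1.g-1 and 40 mL.min-1.g-1.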

Compound 4, intrinsic clearance in microsomes: < 8 mL.min-1.g-1
Compound 4 was reported as a limit; the forecaster's own chance of this, stated with the estimate: 40%; at least 1.5-fold (0.17 log units) between middle value and limit.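

Compound 1 and compound 4 both sit at the same limit in this assay, so no step between them can be read: the limit of < 8 mL.min-1.g-1 in this assay, at which 2 of the 4 values shown sit.

The compounds shown leave open whether pyridin-3-yl in place of 1,3-thiazol-2-yl changes clearance at all.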